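This account rests on a few compounds, and the source may have more. Where it says the series, first, only, none or still open, it means among the compounds named here.

Series of amide-linked aryl compounds examined for tolerance in a toxicity assay on THP-1 cells (Homo sapiens) for inhibition; a higher number here means that more compound is tolerated, a lower number that less compound is tolerated. Compound 1 `Cn1c(-c2ccccc2)cnc1NC(=O)c1ccc(F)cc1` reaches only a limit of the assay, giving > 100000 nM. Compound 3 `COc1ccc(-c2ccnc(NC(=O)c3ccc(F)cc3)c2)cc1` likewise reports a limit, giving > 100000 nM. Compound 2 `COc1ccc(-c2cnc(NC(=O)c3cccnc3)n2C)cc1` also gives a limit, namely > 100000 nM. Within the data shown here, compound 2 thus stands where every value shown stands, at the limit of > 100000 nM in this assay, at which 3 of the 3 values shown sit; no number separates it from compound 1 or compound 3, and no step between measured compounds exists. The unmeasured compound 4 `COc1ccc(-c2cnc(NC(=O)c3ccccc3Br)n2C)cc1` differs from compound 2 in one place: 2-bromophenyl in place of pyridin-3-yl on a carbonyl carbon. With all three values sitting at a limit, no direction for the change can be read from the series, and no step beyond the scatter is expected in this assay. Compound 4 is expected to give 120000 nM in this assay, with a range from 60000 nM to 300000 nM. The expected step that the limit leaves unreadable from compound 2 to compound 4 is most likely to be reported once more as a limit rather than as a number.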

Compound 4, half-maximal cytotoxic concentration: > 100000 nM
Compound 4: a limit, no number; the forecaster's own chance of this, stated with the estimate: 75%; the middle value is on the limit's open side.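

Among these compounds, no step from compound 2 to compound 4 can be read, because both report only a limit: the limit of > 100000 nM in this assay, at which 4 of the 4 values shown sit. The compounds shown leave open whether any change to the shared core or its amide substituents would give a readable number in this assay.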